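The source may hold more compounds than are shown below. What is called first, only, known or untested is meant among the compounds shown, and "the series" means these compounds.

In a toxicity assay on MCF7 cells (Homo sapiens) for cytotoxicity, read by MTT assay, with a stated time of 3 h (a higher number here means a weaker inhibitor, a lower number a stronger inhibitor), compound 1 `COc1ccc2c(c1)CCc1c(-c3ccccc3)c3n(c1-2)[B-](F)(F)[N+]1=C(c2ccc(C)s2)C(Br)=C(c2ccccc2)C1=N3`, which carries 5-methylthiophen-2-yl, gives only a limit, > 50000 nM. Compound 2 `COc1ccc(C2=[N+]3C(=Nc4c(-c5ccccc5)c5c(n4[B-]3(F)F)-c3ccc(OC)cc3CC5)C(c3ccccc3)=C2I)cc1` also gives only a limit, > 50000 nM. Compound 3 `COc1ccc2c(c1)CCc1c(-c3ccccc3)c3n(c1-2)[B-](F)(F)[N+]1=C(c2ccc(C)cc2)C(I)=C(c2ccccc2)C1=N3` likewise gives only a limit, > 50000 nM, and so stands with the others at the limit of > 50000 nM in this assay, at which 3 of the 3 values shown sit. Compound 4 `COc1ccc2c(c1)CCc1c(-c3ccccc3)c3n(c1-2)[B-](F)(F)[N+]1=C(c2ccc(C)s2)C(I)=C(c2ccccc2)C1=N3` differs from compound 3 in carrying 5-methylthiophen-2-yl in place of 4-methylphenyl on a carbon with a double bond to nitrogen. Going by the values given here, the one measured step is a step that the two limits leave unreadable from compound 2 to compound 3, so it offers no size to carry over. No change beyond the scatter is therefore expected in this assay, and the expected step is a number no higher from compound 3 to compound 4 (the limit leaves the size open). Compound 4 is estimated at 50000 nM, within an expected range of 25000 nM to 100000 nM.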

Compound 4, half-maximal inhibitory concentration: > 50000 nM
Compound 4: only a limit was reported; the forecaster's own chance of this, stated with the estimate: 90%; the middle value sits exactly at the limit.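

Going by these compounds alone, compound 4 gives only a limit, > 50000 nM, so no step to it from compound 1, compound 2 or compound 3 can be read in this assay. The compounds shown leave open whether any of these changes alters cytotoxicity, as all sit at one limit: the limit of > 50000 nM in this assay, at which 4 of the 4 values shown sit.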